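A few compounds are considered here, and "the series" means these few. Any claim that something is new, unique, unknown or untested is made for them only; others in the source may bear on it.

Working notes on the series. In a physicochemical assay for lipophilicity, read by HPLC, using the shake flask method (on this read-out lower numbers stand for lower lipophilicity and higher numbers for higher lipophilicity), compound 2 `CCCCC/C(=N\C#N)N(C)Cc1ccc(Cl)nc1` gives 2.3 and sits within the scatter of compound 1 `CCCCCN(Cc1ccc(Cl)nc1)/C(C)=N/C#N` at 2.37 and of compound 3 `CCCCN(Cc1ccc(Cl)nc1)/C(C)=N/C#N` at 2.13 so no order among the three can be read. The next entry is compound 4 `CCCC/C(=N\C#N)N(C)Cc1ccc(Cl)nc1` and its difference from compound 2 is hydrogen in place of methyl on a saturated chain carbon, four bonds along the chain from a carbon with a double bond to nitrogen or in words, hydrogen in place of methyl on a saturated chain carbon, four bonds along the chain from a carbon with a double bond to nitrogen. Cut one bond further out, the same difference reads butyl to propyl. Within the data shown here, the one measured step of this kind is a number 0.24 log units lower from compound 1 to compound 3 (within the scatter) where hydrogen stands in place of methyl on a saturated chain carbon, four bonds along the chain from an amine nitrogen. It is a single pair, and its chain is counted from an amine nitrogen, so it serves only as a guide. On that guide a step of similar size is expected in this assay toward a lower number and within the scatter. The estimated step is a number 0.24 log units lower from compound 2 to compound 4 (within the scatter) and nothing beyond the scatter is expected. In this assay the estimated value of compound 4 is 2.06 with an expected range from 1.84 to 2.28 for now.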

Compound 4, partition coefficient: 1.87
Estimate against measurement, compound 4: 0.19 log units above; low and high end bracket the measured number.
By their numbers in this assay, from the lowest: compounds 4, 3, 2 and 1 (each within the scatter of the next, the first and the last beyond it).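

In this assay, the change of butyl to propyl, with hydrogen in place of methyl on a saturated chain carbon, four bonds along the chain from a carbon with a double bond to nitrogen, gives a number 0.43 log units lower from compound 2 to compound 4 (beyond the scatter) and is the first step of this kind in the series to clear the scatter, so this position registers a loss of one chain carbon as a modest but readable change. The earlier step, a number 0.24 log units lower from compound 1 to compound 3 (within the scatter), runs the same way but stays within the scatter and is counted from an amine nitrogen, so these two single pairs show a shared direction and cannot establish a difference in size between the two chain positions. Nothing on hand accounts for the size of the new step.

From the compounds shown here alone, it remains open whether the step recurs further along the same chain, as propyl to ethyl or ethyl to methyl, or continues in the other direction with a longer chain. Going by these compounds, how a branched chain, a cyclopropyl ring or a chain ending in a hydroxyl group would read at this position is also open.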